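A few compounds are considered here, and "the series" means these few. Any claim that something is new, unique, unknown or untested is made for them only; others in the source may bear on it.

Compound 1 `CC(Oc1ccc(CCC(=O)O)cc1)c1nc(-c2ccccc2)no1` and compound 3 `CC(Oc1ccc(CCC(=O)O)cc1)c1nc(-c2ccc(Cl)cc2)no1` are built on one core; compound 2 `COc1cccc(-c2noc(COc3ccc(CCC(=O)O)cc3)n2)c1` stands on another, and the difference between the two cores is not broken down here. In a functional assay on CHO cells for agonist activity at Free fatty acid receptor 1 (Homo sapiens), read by FLIPR and calcium flux, in the presence of a further agent that is not named here (on this read-out higher numbers stand for an effect only at larger amounts of compound and lower numbers for an effect already at smaller amounts), compound 1 gives 2390 nM, compound 2 gives 2670 nM and compound 3 gives 500 nM. Compound 3 carries chloro in place of hydrogen on an aromatic carbon, and a 4.8-fold lower number from compound 1 to compound 3 (0.68 log units; beyond the scatter). Compound 4 `COc1cccc(-c2noc(COc3ccc(CCC(=O)O)cc3Cl)n2)c1`, not yet measured, carries chloro in place of hydrogen on an aromatic carbon on the core of compound 2. This is the same kind of change, not the same one: in compound 3 the chloro sits para to a large group, in compound 4 ortho to a large group and meta to a 2-carboxyethyl group. A smaller step is expected, a 1.8-fold lower number from compound 2 to compound 4 (0.25 log units; within the scatter) in this assay, as the chloro enters at another place than the one that gave a 4.8-fold lower number from compound 1 to compound 3 (0.68 log units; beyond the scatter). Compound 4 is estimated at 1500 nM, between 500 nM and 4500 nM.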

Compound 4, half-maximal effective concentration: 3000 nM
Compound 4: middle estimate off by 2.0-fold (0.30 log units), on the low side; measured number inside the range.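

In this assay the new step is a 1.1-fold higher number from compound 2 to compound 4 (0.05 log units; within the scatter), so chloro at this place leaves compound 2 and compound 4 indistinguishable. Set beside the earlier step, the same kind of change does not carry over from one core to the other with one fixed size: the same change on two cores in this assay, a 4.8-fold lower number (0.68 log units; beyond the scatter) from compound 1 to compound 3 and a 1.1-fold higher number (0.05 log units; within the scatter) from compound 2 to compound 4, 5.4-fold (0.73 log units) apart, beyond the scatter of two such steps The two steps differ in both the core and the place of the chloro, and these two pairs cannot separate those two differences.

Still open, as far as these compounds go, is what chloro would do on the core of compound 2 at the place it holds in compound 3. Also open, from the compounds shown here alone, is whether a smaller fluoro or a nitrile at either place would behave like chloro.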